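The source may report more compounds than this note shows. Statements on the series, on what has been measured and on what is new or still open speak of the compounds shown alone.

Compound 1 `CCCCn1ccnc1-c1cc(OC)c(OC)c(OC)c1` carries a butyl on an aromatic nitrogen of its core. Going by the values given here, in a functional assay on MDA-MB-468 cells (Homo sapiens) for antiproliferative activity, read by MTT assay, with a stated time of 72 h (a higher number here means a weaker inhibitor, a lower number a stronger inhibitor), compound 1 gives 44100 nM, the highest of the two numbers measured so far. Among the compounds with values here, the only other measured compound, compound 2 `COc1cc(-c2nccn2-c2ccc3[nH]ccc3c2)cc(OC)c1OC`, gives 2300 nM in this assay, a number far below that of compound 1 and well beyond the scatter. Compound 3 `COc1ccc(-n2ccnc2-c2cc(OC)c(OC)c(OC)c2)cc1` has not yet been measured in this assay. It differs from compound 1 in one place: 4-methoxyphenyl in place of butyl on an aromatic nitrogen. Within the data shown here, no step between two measured compounds matches this change, so the pair of compound 1 and compound 2 is the only guide to what a ring-bearing group on that aromatic nitrogen may do, and there the number fell sharply. Compound 3 is therefore expected to give a clearly lower number than compound 1 in this assay. The step expected from this change is a 44-fold lower number from compound 1 to compound 3 (1.64 log units; beyond the scatter), well beyond the scatter. The estimate for compound 3 in this assay is 1000 nM, expected to lie between 150 nM and 6000 nM.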

Compound 3, half-maximal inhibitory concentration: 500 nM
The estimate for compound 3 lay 2.0-fold (0.30 log units) above the measured number; low and high end bracket the measured number.
By their numbers in this assay, from the lowest: compound 3; then compound 2; then compound 1.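

In this assay, going by these compounds alone, the exchange of butyl for 4-methoxyphenyl on the aromatic nitrogen gives an 88-fold lower number from compound 1 to compound 3 (1.95 log units; beyond the scatter) and is the first change at this position that can be read as a direct step, tying a six-membered aromatic ring of carbon only at this place to a far lower number than the butyl chain. Compound 2, which also carries a ring-bearing group on this nitrogen, gives 2300 nM while compound 3 gives 500 nM in this assay, so these printed numbers show that the presence of a ring does not alone set the value and that the choice of ring-bearing group still counts. No measurement at hand accounts for the size of this step.

What the compounds shown leave open is how much of the step belongs to the ring and how much to its methoxy group, a question that a plain phenyl on this nitrogen would separate. Also open, from the compounds shown here alone, is whether a benzyl group, with a carbon link to the ring, or a pyridyl group, with a nitrogen in the ring, would keep the number near that of compound 3.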